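Urea to amide exchange on the phenol analogue

The source may report more compounds than this note shows. Statements on the series, on what has been measured and on what is new or still open speak of the compounds shown alone.

Three compounds of the series carry numbers in a functional assay on SK-MEL-2 cells (Homo sapiens) for antiproliferative activity, read by sulforhodamine B assay, with a stated time of 48 h; a lower number here means a stronger inhibitor, a higher number a weaker inhibitor. Among the compounds with values here, compound 1 `COc1cc(-c2nn(-c3ccc(NC(=O)Nc4ccc(Cl)c(C(F)(F)F)c4)cc3)cc2-c2ccncc2)ccc1Cl` gives 1630 nM, and compound 2 `COc1cc(-c2nn(-c3ccc(NC(=O)c4ccc(Cl)c(Cl)c4)cc3)cc2-c2ccncc2)ccc1Cl` gives 5740 nM; the step of a 3.5-fold higher number from compound 1 to compound 2 (0.55 log units; beyond the scatter) is the one exchange of the urea for the amide that has been measured. Compound 3 `O=C(Nc1ccc(-n2cc(-c3ccncc3)c(-c3ccc(Cl)c(O)c3)n2)cc1)Nc1ccc(Cl)c(C(F)(F)F)c1` gives 1700 nM, and the step of a 1.0-fold higher number from compound 1 to compound 3 (0.02 log units; within the scatter) shows that removing the methyl from the oxygen leaves the number unchanged within the scatter; compound 3 and compound 1 therefore sit together, while compound 2 lies beyond the scatter above both.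

Compound 4 `O=C(Nc1ccc(-n2cc(-c3ccncc3)c(-c3ccc(Cl)c(O)c3)n2)cc1)c1ccc(Cl)c(Cl)c1` is not yet measured. It differs from compound 3 in one place: 3,4-dichlorophenyl in place of (4-chloro-3-(trifluoromethyl)phenyl)amino on a carbonyl carbon. This is the same exchange as between compound 1 and compound 2, now on the phenol rather than the methyl ether. Since the methyl-to-hydrogen change did not move the number, the amide exchange is expected to act as before, giving a modest higher number. The expected step is a 3.5-fold higher number from compound 3 to compound 4 (0.54 log units; beyond the scatter). Compound 4 is estimated at 5900 nM, with a range from 2800 nM to 12500 nM.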

Compound 4, half-maximal inhibitory concentration: 4050 nM
The estimate for compound 4 lay 1.5-fold (0.16 log units) above the measured number; the range from low to high includes it.
By their numbers in this assay, from the lowest: compounds 1 and 3 (each within the scatter of the next); then compounds 4 and 2 (each within the scatter of the next).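

In this assay, the exchange of (4-chloro-3-(trifluoromethyl)phenyl)amino for 3,4-dichlorophenyl on the carbonyl carbon also raises the number on the phenol, with a 2.4-fold higher number from compound 3 to compound 4 (0.38 log units; beyond the scatter), so the step is not tied to the methyl ether and has a similar size on both cores: the same change on two cores in this assay, a 3.5-fold higher number (0.55 log units; beyond the scatter) from compound 1 to compound 2 and a 2.4-fold higher number (0.38 log units; beyond the scatter) from compound 3 to compound 4, 1.5-fold (0.17 log units) apart, within the scatter of two such steps

The change from methyl to hydrogen on the oxygen, until now seen only on the urea, also stays within the scatter on the amide, with a 1.4-fold lower number from compound 2 to compound 4 (0.15 log units; within the scatter): the same change on two cores in this assay, a 1.0-fold higher number (0.02 log units; within the scatter) from compound 1 to compound 3 and a 1.4-fold lower number (0.15 log units; within the scatter) from compound 2 to compound 4, 1.5-fold (0.17 log units) apart, within the scatter of two such steps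

Across these four compounds the two changes therefore read as independent, and none goes against this.

Each exchange replaces the amino link and the trifluoromethyl together, and the compounds shown do not separate the two. Also open, on these data alone, is how a longer chain on the oxygen, such as an ethyl or propyl ether, would read.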